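Chloro for methoxy on the shared core

A few compounds are considered here, and "the series" means these few. Any claim that something is new, unique, unknown or untested is made for them only; others in the source may bear on it.

In a functional assay on NCI-H460 cells (Homo sapiens) for cytotoxicity, read by MTT assay, with a stated time of 48 h (a higher number here means a weaker inhibitor, a lower number a stronger inhibitor), compound 1 `COc1cc(/C=C/C(=O)/C=C/c2nc3ccccc3n2C)ccc1O` gives 7000 nM while compound 2 `COc1ccc2c(c1)nc(/C=C/C(=O)/C=C/c1ccc(O)c(OC)c1)n2C` gives 12700 nM within the scatter of compound 1. Within the data shown here, compound 2 therefore does not stand apart from the only other measured member of the series. Among the measured compounds shown here, the single measured step, methoxy in place of hydrogen on an aromatic carbon, is a 1.8-fold higher number from compound 1 to compound 2 (0.26 log units; within the scatter) and no other step is available for comparison.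

Compound 3 `COc1cc(/C=C/C(=O)/C=C/c2nc3cc(Cl)ccc3n2C)ccc1O` follows from compound 2 by chloro in place of methoxy on an aromatic carbon at the same carbon that holds hydrogen in compound 1. No chloro compound has been measured, so the size of this change is not shown directly. For the measured compounds named here, because a 1.8-fold higher number from compound 1 to compound 2 (0.26 log units; within the scatter) is the only measured change at that carbon, no step beyond the scatter is expected in this assay for the swap to chloro. The expected step is a 1.4-fold lower number from compound 2 to compound 3 (0.15 log units; within the scatter) and it rests on that one comparison. Compound 3 is estimated at 9000 nM with an expected range from 4000 nM to 20000 nM for now.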

Compound 3, half-maximal inhibitory concentration: 8900 nM
Compound 3: middle estimate off by 1.0-fold (0.00 log units), on the high side; low and high end bracket the measured number.
By their numbers in this assay, from the lowest: compounds 1, 3 and 2 (each within the scatter of the next).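

Chloro in place of methoxy gives a 1.4-fold lower number from compound 2 to compound 3 (0.15 log units; within the scatter) and chloro in place of hydrogen gives a 1.3-fold higher number from compound 1 to compound 3 (0.10 log units; within the scatter) at this aromatic carbon of the shared core in this assay so hydrogen, methoxy and chloro now form a set of three in which no pair separates. The earlier pair set a single group against hydrogen, whereas this result adds a second group that differs from methoxy in its count, with one heavy atom in place of two and no hydrogen-bond acceptor in place of one, and the read-out still stays within the scatter across that difference. No supporting measurement is available to interpret this result.

As far as these compounds go, whether an amine, a carboxylic acid or a longer alkoxy chain at this carbon would give a step beyond the scatter remains open, since the three groups in hand span only a narrow range of structures. From the compounds shown here alone, it also remains open whether changes elsewhere on the shared core would give larger steps, and whether the same lack of separation would hold in any other cell line.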